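Exchange of a Five-Membered Ring: Compound 3 to Compound 4

The source may report more compounds than this note shows. Statements on the series, on what has been measured and on what is new or still open speak of the compounds shown alone.

Measured compounds:
compound 1, `Cc1nn(C)c(C)c1-c1ccc(-c2nnc(N(C)Cc3ccc4nccn4c3)o2)cc1`, 3160 nM
compound 2, `COc1cc(-c2c(C)nn(C)c2C)ccc1-c1nnc(N(C)Cc2ccc3nccn3c2)o1`, 2000 nM
compound 3, `Cc1cc(-c2c(C)n[nH]c2C)ccc1-c1nnc(N(C)Cc2ccc3nccn3c2)o1`, 15800 nM

All three share one core and were tested in an assay on COS-7 cells for inhibition of tyrosine-protein kinase receptor UFO (Homo sapiens), read by ELISA, with a stated time of 1 h; on this read-out lower numbers stand for stronger inhibition and higher numbers for weaker inhibition. Compound 3 stands at the highest number of the three; its distance to compound 1 and to compound 2 is beyond the usual scatter, so it is the weakest of this small set. Going by the values given here, only one pair differs in a single place: a 1.6-fold lower number from compound 1 to compound 2 (0.20 log units; within the scatter). Among the compounds with values here, compound 3 and compound 1 differ in two places at once, so their values show only that compound 3 lies well above compound 1.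

Compound 4, `Cc1cc(-c2c(C)nc(C)n2C)ccc1-c1nnc(N(C)Cc2ccc3nccn3c2)o1`, has not yet been measured. It differs from compound 3 in one place: 1,2,4-trimethyl-1H-imidazol-5-yl in place of 3,5-dimethyl-1H-pyrazol-4-yl on an aromatic carbon. Within the data shown here, no measured step covers this exchange; the one tallied step concerns a methoxy and is within the scatter. What the data do offer is that compound 1 and compound 2 carry a group with no hydrogen-bond donor at this position, as compound 4 will, and both gave numbers far below compound 3. For compound 4 in this assay an estimate of 4000 nM is therefore expected, with a range from 1000 nM to 16000 nM. This estimate means a step of a 4.0-fold lower number from compound 3 to compound 4 (0.60 log units; beyond the scatter) is expected.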

Compound 4, half-maximal inhibitory concentration: 5010 nM
Compound 4: middle estimate off by 1.3-fold (0.10 log units), on the low side, within the range that was stated.
By their numbers in this assay, from the lowest: compounds 2, 1 and 4 (each within the scatter of the next, the first and the last beyond it); then compound 3.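

Going by these compounds alone, exchanging 3,5-dimethyl-1H-pyrazol-4-yl for 1,2,4-trimethyl-1H-imidazol-5-yl on this aromatic carbon, para to a large group, gives in this assay a 3.2-fold lower number from compound 3 to compound 4 (0.50 log units; beyond the scatter) and is the first single-place step in the set to lie beyond the usual scatter, so this position can move the read-out, though only modestly here. The exchange alters several things at once: the ring that leaves has 7 heavy atoms, 1 hydrogen-bond donor and 1 hydrogen-bond acceptor, while the ring that enters has 8 heavy atoms, 0 hydrogen-bond donors and 2 hydrogen-bond acceptors, and this one step cannot say which of these differences counts. No measurement shown here gives a reason for the step.

No pair among the compounds shown separates the change of ring from the methyl on the ring nitrogen, so the share of each in the step stays unknown. Also open, going by these compounds, is how this same aromatic carbon would respond to quite different groups, such as a plain phenyl ring, a primary amine or a carboxylic acid.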